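A few compounds are considered here, and "the series" means these few. Any claim that something is new, unique, unknown or untested is made for them only; others in the source may bear on it.

Working notes on the series.

Three compounds have numbers in an assay on membranes from brain for binding affinity to Adrenergic receptor alpha-1 (Rattus norvegicus); a lower number here means a stronger inhibitor, a higher number a weaker inhibitor. Compound 1 `c1ccc(CC2CCN(Cc3nc4ccccc4[nH]3)CC2)cc1` gives 2800 nM. Compound 2 `N#Cc1ccc2[nH]c(Cc3ccc(Oc4ccccc4)cc3)nc2c1` gives 3400 nM. Compound 3 `Oc1cccc2[nH]c(Cc3ccc(Oc4ccccc4)cc3)nc12` gives 5500 nM. Compound 2 sits between the other two numbers, and all three values lie within the usual scatter of one another, so no order among them can be read from these data.

The next step goes from compound 2 to compound 4 `CCCS(=O)(=O)Nc1ccc2[nH]c(Cc3ccc(Oc4ccccc4)cc3)nc2c1`. The change is (propylsulfonyl)amino in place of cyano on an aromatic carbon, placed on an aromatic carbon of a six-membered aromatic ring of carbon only, part of a fused system of two rings, meta to a fused ring and para to a fused ring. For the measured compounds named here, no measured pair in this set carries the same change, so there is nothing to anchor the size of the step; the three numbers in hand all fall within the scatter of one another despite different groups on the shared core, which argues for expecting no step beyond the scatter.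

For compound 4 the expected step from compound 2 in this assay is a 1.1-fold lower number from compound 2 to compound 4 (0.05 log units; within the scatter), with no direction beyond the scatter. Compound 4 is therefore estimated at 3000 nM, in a range from 800 nM to 12000 nM.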

Compound 4, half-maximal inhibitory concentration: 4800 nM
Beside the measured number, compound 4's estimate is 1.6-fold (0.20 log units) below it; low and high end bracket the measured number.
By their numbers in this assay, from the lowest: compounds 1, 2, 4 and 3 (each within the scatter of the next).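

In this assay, for the compounds shown here, the replacement at this aromatic carbon, meta to a fused ring and para to a fused ring, gives a 1.4-fold higher number from compound 2 to compound 4 (0.15 log units; within the scatter) and provides the first one-place comparison. The step lies within the scatter, although (propylsulfonyl)amino brings 7 heavy atoms and 1 hydrogen-bond donor where cyano has 2 heavy atoms and none, so this position shows no readable difference between these two groups. Nothing measured on these compounds accounts for this result.

This single pair leaves open whether other groups at the same carbon, such as an amine, a carboxylic acid or a longer chain on the sulfonyl, would also stay within the scatter. It also leaves open whether the same replacement would behave alike at other carbons of this ring.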